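Replacing the outer aromatic ring: compound 1 to compound 4

The compounds below may be only part of what the source reports. "The series", "measured", "known", "first", "only" and "open" are said of these compounds alone.

Measured compounds:
compound 1 `COc1ccc(-c2ccc(OCc3cc(C(=O)NS(=O)(=O)c4ccccc4)oc3C)cc2)c(C)c1`, 21 nM
compound 2 `COc1ccc(-c2ccc(OCc3cc(C(=O)NS(=O)(=O)c4ccc(C)cn4)oc3C)cc2)cc1`, 15 nM
compound 3 `COc1ccc(-c2ccc(OCc3cc(C(=O)NS(=O)(=O)c4c(C)noc4C)oc3C)cc2)c(C)c1`, 24 nM

In an assay on cells for displacement of a labelled ligand from prostaglandin E2 receptor EP4 subtype (Homo sapiens), read by scintillation counting (a higher number here means a weaker inhibitor, a lower number a stronger inhibitor), compound 1 gives 21 nM, the second highest of the three numbers; compound 3 lies nearest at 24 nM and compound 2 furthest at 15 nM, both within the scatter. Among the measured compounds shown here, the only one-point step in hand, a 1.1-fold higher number from compound 1 to compound 3 (0.06 log units; within the scatter), concerns the group on the sulfonyl sulfur, not the part that changes here. Compound 4 `COc1ccc(-c2ccc(OCc3cc(C(=O)NS(=O)(=O)c4ccccc4)oc3C)cc2)nc1` differs from compound 1 by 5-methoxypyridin-2-yl in place of 4-methoxy-2-methylphenyl on an aromatic carbon. For the measured compounds named here, no measured pair isolates this change; compound 2, which differs from compound 1 at two places, sits within the scatter of compound 1. A step within the scatter is therefore expected. For compound 4 the estimate in this assay is 30 nM, range 10 nM to 90 nM. The step expected is a 1.4-fold higher number from compound 1 to compound 4 (0.15 log units; within the scatter).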

Compound 4, inhibition constant in the prostaglandin E2 receptor EP4 subtype assay: 22 nM
Compound 4: middle estimate off by 1.4-fold (0.13 log units), on the high side; the range from low to high includes it.
By their numbers in the prostaglandin E2 receptor EP4 subtype assay, from the lowest: compounds 2, 1, 4 and 3 (each within the scatter of the next).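

In the prostaglandin E2 receptor EP4 subtype assay compound 1 gives 21 nM and compound 4 gives 22 nM, and the step of a 1.0-fold higher number from compound 1 to compound 4 (0.02 log units; within the scatter) shows that at this position, on an aromatic carbon para to a large group, 5-methoxypyridin-2-yl and 4-methoxy-2-methylphenyl cannot be told apart. In a physicochemical assay for solubility, in phosphate buffer, with a stated time of 24 h, at pH 7.4 (a higher number here means a more soluble compound, a lower number a less soluble compound), compound 1 gives 20 ug/mL and compound 4 gives 30 ug/mL, and the step of a 1.5-fold higher number from compound 1 to compound 4 (0.18 log units; within the scatter) also stays within the scatter, so this change separates the two compounds in neither read-out. Nothing measured here gives a reason for either result.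

Open, from the compounds shown here alone, is how an amine or a carboxylic acid on this ring would read in the prostaglandin E2 receptor EP4 subtype assay and the physicochemical assay. Also open, going by these compounds, is whether the same replacement holds with the 3,5-dimethyl-1,2-oxazol-4-yl group of compound 3 on the sulfonyl sulfur.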